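A few compounds are considered here, and "the series" means these few. Any claim that something is new, unique, unknown or untested is made for them only; others in the source may bear on it.

The series shares a core with a propargyloxy aryl group joined through a double-bonded chain carbon to a carbonyl, and the compounds differ in what sits on that carbonyl. Compound 1 `C#CCOc1ccc(/C=C/C(=O)c2cccc(C)c2)cc1OC` carries 3-methylphenyl there, and in a functional assay on CCRF-CEM cells (Homo sapiens) for cytotoxicity, with a stated time of 72 h (a lower number here means a stronger inhibitor, a higher number a weaker inhibitor), compound 1 gives 8820 nM. Among the compounds with values here, compound 3 `C#CCOc1ccc(/C=C/C(=O)c2ccc(C(C)C)cc2)cc1CC=C`, which carries an isopropyl-bearing phenyl on the carbonyl and an allyl chain on the core, gives 11900 nM in this assay, a value that lies within the usual scatter of the one for compound 1, so the two cannot be ordered. Compound 2 `C#CCOc1ccc(C(CC(=O)c2cccc(Br)c2)CC(=O)c2cccc(Br)c2)cc1OC`, in which the double bond is absent and two bromophenyl ketone arms branch from a single carbon, reaches only the limit of this assay, > 50000 nM, so no number is known for it (the limit of > 50000 nM in this assay, at which 1 of the 3 values shown sits).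

Compound 4 `C#CCOc1ccc(/C=C/C(=O)c2ccn(C)c2)cc1OC` has not yet been measured in this assay. It differs from compound 1 in one place: 1-methyl-1H-pyrrol-3-yl in place of 3-methylphenyl on a carbonyl carbon. Within the data shown here, no measured pair shows such a step, so its size is not known from the data. Compound 4 is expected to give 18000 nM in this assay, with a range from 5000 nM to 50000 nM, which means an expected step from compound 1 to compound 4 of a 2.0-fold higher number from compound 1 to compound 4 (0.31 log units; beyond the scatter), a loss somewhat beyond the scatter but not a collapse to the limit.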

Compound 4, half-maximal inhibitory concentration: > 50000 nM
Compound 4 was reported as a limit; the forecaster's own chance of this, stated with the estimate: 25%; middle value at least 2.7-fold (0.44 log units) away from the limit.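

With the rest of the structure unchanged, 1-methyl-1H-pyrrol-3-yl in place of 3-methylphenyl on a carbonyl carbon gives an at least 5.6-fold higher number from compound 1 to compound 4 (0.75 log units; beyond the scatter) in this assay. Within the data shown here, this is the first change that can be read in one place alone, and it shows that the group on this carbonyl carbon can decide whether a measurable value remains: the six-membered carbon ring of the 3-methylphenyl group gives a number, whereas the five-membered ring with one nitrogen does not. Compound 4 stands only as a limit, so the step has a lower bound and no upper one, and compound 4 now shares that limit with compound 2: the limit of > 50000 nM in this assay, at which 2 of the 4 values shown sit.

The compounds shown do not separate the change in ring size, the entry of the ring nitrogen and the loss of the methyl group on the phenyl ring from one another. From the compounds shown here alone, it remains open whether an unsubstituted phenyl, a pyridin-3-yl or a thiophen-3-yl group on this carbonyl carbon would keep a measurable value in this assay or also reach the limit.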